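Three Measured Compounds and a Fourth Awaiting Measurement

A few compounds are considered here, and "the series" means these few. Any claim that something is new, unique, unknown or untested is made for them only; others in the source may bear on it.

Compound 1 `COc1ccc(CS(=O)(=O)/C=C/c2ccc(F)cc2)cc1`: 2500 nM
Compound 2 `COc1ccc(CS(=O)(=O)/C=C/c2ccc(F)cc2OC)cc1`: 20000 nM
Compound 3 `COc1ccc(CS(=O)(=O)/C=C/c2ccc(OC)cc2OC)cc1`: > 20000 nM

Of the compounds shown here, three have been tested in a functional assay on H157 cells (Homo sapiens) for antiproliferative activity, read by trypan blue exclusion; a higher number here means a weaker inhibitor, a lower number a stronger inhibitor. Compound 1 gives 2500 nM. Compound 2 differs from compound 1 in a single place: methoxy in place of hydrogen on an aromatic carbon. That change produced an 8.0-fold higher number from compound 1 to compound 2 (0.90 log units; beyond the scatter). Compound 3 is one further change away from compound 2, and in this assay compound 3 gives > 20000 nM, which is a limit of the assay and not a number. The step is therefore a number no lower from compound 2 to compound 3 (the limit leaves the size open), and the weight of this rests on (the limit of > 20000 nM in this assay, at which 1 of the 3 values shown sits).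

Compound 4 `COc1ccc(CS(=O)(=O)/C=C/c2c(OC)cc(OC)cc2OC)cc1` has not yet been measured. It differs from compound 3 in one place: methoxy in place of hydrogen on an aromatic carbon. The difference between the core of compound 3 and the core of compound 1 is not broken down here. The change from compound 3 to compound 4 is the same kind of change as that from compound 1 to compound 2, but not the same: in compound 2 the entering methoxy sits ortho to a large group and meta to a fluoro group, whereas in compound 4 it sits ortho to a large group and meta to two methoxy groups.

The step from compound 3 to compound 4 is expected to be a step that the limit leaves unreadable from compound 3 to compound 4, an expectation resting on the earlier 8.0-fold higher number from compound 1 to compound 2 (0.90 log units; beyond the scatter) for the same kind of change. For compound 4 the estimate in this assay is 40000 nM, most likely reported again as a limit.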

Compound 4, half-maximal inhibitory concentration: 30 nM
Estimate against measurement, compound 4: 1300-fold (3.12 log units) above; the measured number lies below the stated range.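

In this assay, a methoxy in place of hydrogen on an aromatic carbon of compound 3 gave an at least 660-fold lower number from compound 3 to compound 4 (2.82 log units; beyond the scatter), so a change that made the number higher on one core made it far lower on another. Going by these compounds, compound 3 gives > 20000 nM, which is a limit of the assay and not a number, so the exact size of this step stays unknown: the limit of > 20000 nM in this assay, at which 1 of the 4 values shown sits. Set beside the earlier step, the result shows that the effect of this change cannot simply be carried from one core to another in this series, although two pairs of compounds neither explain the difference nor give a rule for any other core: the same change on two cores in this assay, an 8.0-fold higher number (0.90 log units; beyond the scatter) from compound 1 to compound 2 and an at least 660-fold lower number (2.82 log units; beyond the scatter) from compound 3 to compound 4, at least 5300-fold (3.72 log units) apart, beyond the scatter of two such steps.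

The compounds shown leave open whether the large drop in the number belongs to methoxy itself or whether other groups in the same place on the core of compound 3 would give a similar result. A hydroxyl group, an amine, a carboxylic acid or a longer chain such as ethoxy at that position would help to separate these two possibilities.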